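Chloro for methoxy on the anilide of the diaryl ether series

This account rests on a few compounds, and the source may have more. Where it says the series, first, only, none or still open, it means among the compounds named here.

Compound 2 `COc1ccc(NC(=O)c2cc(Oc3ccc(/C=C/c4ccncc4)cc3)ccn2)cc1` gives 25600 nM in a functional assay on A549 cells (Homo sapiens) for antiproliferative activity, read by CCK-8 assay, with a stated time of 48 h (a higher number here means a weaker inhibitor, a lower number a stronger inhibitor), the higher of the two numbers recorded so far. Compound 1 `O=C(Nc1ccc(Cl)cc1)c1cc(Oc2ccc(/C=C/c3ccccn3)cc2)ccn1` gives 16200 nM in this assay, and the two values lie within the scatter of each other. Compound 3 `O=C(Nc1ccc(Cl)cc1)c1cc(Oc2ccc(/C=C/c3ccncc3)cc2)ccn1` differs from compound 2 by chloro in place of methoxy on an aromatic carbon. Among the compounds with values here, no measured pair shows this change, so nothing recorded sets its size. The expected step is a 1.4-fold lower number from compound 2 to compound 3 (0.15 log units; within the scatter), a slight move toward a lower number that stays within the scatter. Compound 3 is estimated at 18000 nM, with a range from 7000 nM to 45000 nM.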

Compound 3, half-maximal inhibitory concentration: 62100 nM
Compound 3: middle estimate off by 3.5-fold (0.54 log units), on the low side; the measured number lies above the stated range.
By their numbers in this assay, from the lowest: compounds 1 and 2 (each within the scatter of the next); then compound 3.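

With pyridin-4-yl held, chloro in place of methoxy on the aromatic carbon para to a large group is not a neutral swap in this assay: the change gives a 2.4-fold higher number from compound 2 to compound 3 (0.38 log units; beyond the scatter). With chloro held, pyridin-4-yl in place of pyridin-2-yl gives a 3.8-fold higher number from compound 1 to compound 3 (0.58 log units; beyond the scatter), so the series responds at both places, and compound 3 is the weakest of the three. No available evidence accounts for either step. Open, on these data alone, are whether an amine or a trifluoromethyl group on that carbon would give a lower number than compound 2, and whether the chloro-for-methoxy step keeps its size with pyridin-2-yl in place.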